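Replacing a hydroxyphenyl end with a dichlorophenyl end

The source may hold more compounds than are shown below. What is called first, only, known or untested is meant among the compounds shown, and "the series" means these compounds.

Compound 1 `CN(C)CCn1cnnc1-c1cc(Oc2ccc(NC(=O)N/N=C/c3cccc(O)c3)cc2F)ccn1` has no number in an ADME assay on WI-38 cells (Homo sapiens) for cytotoxicity, read by MTT assay, with a stated time of 72 h; on this read-out higher numbers stand for weaker inhibition and lower numbers for stronger inhibition: its result there stands as "not determined" (no result reported), so it cannot be placed on the scale at all. Two companions sharing its core were measured. Compound 2 `CN(C)CCn1cnnc1-c1cc(Oc2ccc(NC(=O)N/N=C/c3c(O)ccc4ccccc34)cc2F)ccn1` gives 3250 nM in this assay, and compound 3 `CN(C)CCn1cnnc1-c1cc(Oc2ccc(NC(=O)N/N=C/c3ccc(F)cc3)cc2F)ccn1` gives 3980 nM. For the measured compounds named here, the one single-point step among the measured compounds, a 1.2-fold higher number from compound 2 to compound 3 (0.09 log units; within the scatter), exchanges the group on the carbon with a double bond to nitrogen, the same place where compound 4 departs from compound 1.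

Compound 4 `CN(C)CCn1cnnc1-c1cc(Oc2ccc(NC(=O)N/N=C/c3ccc(Cl)cc3Cl)cc2F)ccn1` carries the change (2,4-dichlorophenyl in place of 3-hydroxyphenyl on a carbon with a double bond to nitrogen). Going by the values given here, the only measured step at this place shifted the number within the usual scatter, and a comparable outcome is expected here: no step beyond the scatter in either direction. Compound 1 offers no anchor of its own, so the expectation rests on compound 2 with 3250 nM and compound 3 with 3980 nM, both near the same level. Compound 4 is therefore expected to give about 3600 nM in this assay, with a plausible range from 1500 nM to 9000 nM.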

Compound 4, half-maximal inhibitory concentration: 4760 nM
Compound 4: the middle estimate sits 1.3-fold (0.12 log units) below what was measured; the measured number falls inside the stated range.
By their numbers in this assay, from the lowest: compounds 2, 3 and 4 (each within the scatter of the next).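

In this assay, compound 4 stands level with the two earlier compounds: exchanging the end group gives no step beyond the usual scatter (a 1.2-fold higher number from compound 3 to compound 4 (0.08 log units; within the scatter)) and none when the comparison starts from the larger end group of compound 2 (a 1.5-fold higher number from compound 2 to compound 4 (0.17 log units; within the scatter)). Until now a single exchange at this carbon could be read, whereas three end groups can now be compared, and 2-hydroxynaphthalen-1-yl, 4-fluorophenyl and 2,4-dichlorophenyl all leave the number within the scatter, a pattern that holds only for compounds 2, 3 and 4. No measurement available here accounts for this flat result.

From the compounds shown here alone, compound 1 has no number, so the steps linking its 3-hydroxyphenyl end to the other compounds cannot be read, and the exchange from that end to 2,4-dichlorophenyl remains unknown in size and direction. Going by these compounds, it also remains open whether a phenyl ring carrying an amine or a carboxylic acid, or a longer chain in place of the ring at this carbon, would move the number beyond the scatter.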